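Methoxy in place of piperazin-1-yl: working notes

A few compounds are considered here, and "the series" means these few. Any claim that something is new, unique, unknown or untested is made for them only; others in the source may bear on it.

Measured so far in an ADME assay on HepG2 cells (Homo sapiens) for cytotoxicity; on this read-out higher numbers stand for lower toxicity in this test and lower numbers for higher toxicity in this test:
- compound 1 `CN(C)CC#Cc1cc2c(Nc3ccc(OCc4cccc(F)c4)c(Cl)c3)ncnc2s1`: > 32 uM
- compound 2 `Fc1cccc(COc2ccc(Nc3ncnc4sc(C#CCN5CCNCC5)cc34)cc2Cl)c1`: 7.7 uM

The value of compound 1 is a limit of the assay and not a number. Among the compounds with values here, compound 2, at 7.7 uM, holds the only true number so far.

The next compound, compound 3 `COCC#Cc1cc2c(Nc3ccc(OCc4cccc(F)c4)c(Cl)c3)ncnc2s1`, carries methoxy in place of piperazin-1-yl on a saturated chain carbon bound to a triple-bonded carbon.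

Within the data shown here, one measured step bears on this place, an at least 4.1-fold lower number from compound 1 to compound 2 (0.61 log units; beyond the scatter), where piperazin-1-yl is the group that enters. On these data alone, its full size stays open, given (the limit of > 32 uM in this assay, at which 1 of the 2 values shown sits). Removing piperazin-1-yl is therefore expected to move the number upward, beyond the scatter, though methoxy is not the dimethylamino of compound 1. The expected change is a 2.9-fold higher number from compound 2 to compound 3 (0.46 log units; beyond the scatter). The estimate for compound 3 is 22 uM, with an expected range from 10 uM to 50 uM.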

Compound 3, half-maximal toxic concentration: 9.5 uM
Compound 3: the middle estimate sits 2.3-fold (0.36 log units) above what was measured, and the stated range ends above it.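

In this assay, methoxy and piperazin-1-yl on a saturated chain carbon bound to a triple-bonded carbon read alike, with a 1.2-fold higher number from compound 2 to compound 3 (0.09 log units; within the scatter), so the number at this place does not hang on piperazin-1-yl alone. Dimethylamino now stands apart from both groups, not only from piperazin-1-yl, as methoxy in its place gives an at least 3.3-fold lower number from compound 1 to compound 3 (0.52 log units; beyond the scatter), and the full size of that step stays open: the limit of > 32 uM in this assay, at which 1 of the 3 values shown sits. For compound 1, the value > 32 uM is a limit of the assay and not a number.

On these data alone, it remains open whether another simple amine at this place, such as diethylamino or morpholin-4-yl, would read like dimethylamino or like the other two groups. The compounds shown also say nothing on a carboxylic acid or a longer chain here.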